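The compounds below may be only part of what the source reports. "The series", "measured", "known", "first", "only" and "open" are said of these compounds alone.

Compound 1 `CCCC[C@@H](/C=C\[C@@H]1OC(=O)C=C[C@@H]1O)OC(C)=O`: 3.2 ug/mL
Compound 2 `CCCC[C@@H](/C=C\[C@@H]1OC(=O)C=C[C@@H]1OC(C)=O)OC(C)=O`: 1.8 ug/mL

Among the measured compounds shown here, in a functional assay on KB-V1 cells (Homo sapiens) for cytotoxicity, read by sulforhodamine B assay, with a stated time of 72 h (a higher number here means that more compound is needed for the effect, a lower number that less compound is needed), compound 2 holds one of two numbers that sit within the scatter of each other, the only measured step being a 1.8-fold lower number from compound 1 to compound 2 (0.25 log units; within the scatter). Compound 3 `CCCC[C@H](O)/C=C\[C@@H]1OC(=O)C=C[C@@H]1OC(C)=O` differs from compound 2 by hydrogen in place of acetyl on an oxygen on a saturated carbon. For the measured compounds named here, the one step in hand, a 1.8-fold lower number from compound 1 to compound 2 (0.25 log units; within the scatter), concerns an acetyl on a different oxygen and stayed within the scatter, so it bears only loosely on this change. Compound 3 is therefore expected to show a 1.4-fold higher number from compound 2 to compound 3 (0.14 log units; within the scatter), nothing beyond the scatter. Compound 3 is estimated at 2.5 ug/mL, with a range from 1.2 ug/mL to 5.5 ug/mL.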

Compound 3, concentration for half-maximal effect: 2 ug/mL
For compound 3 the middle estimate is 1.3-fold (0.10 log units) above the measured one; low and high end bracket the measured number.
By their numbers in this assay, from the lowest: compounds 2, 3 and 1 (each within the scatter of the next).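

In this assay, the change from acetoxy to hydroxy on an oxygen on a saturated carbon gives a 1.1-fold higher number from compound 2 to compound 3 (0.05 log units; within the scatter). The earlier step concerned the acetyl on the other oxygen, so this result adds that the acetyl at this position can also give way to hydrogen without a change beyond the scatter. No available evidence accounts for this result.

The compounds shown leave open whether an amine or a longer acyl chain at this oxygen would move the number beyond the scatter. They also leave open what a free hydroxy on both oxygens would give.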